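Shifting the Nitro Group Across the Ring in Compound 3

The source may report more compounds than this note shows. Statements on the series, on what has been measured and on what is new or still open speak of the compounds shown alone.

Compound 1 `CCOC(=O)C1=C(C)NC(=O)NC1c1cn(C(=O)CNc2ccc([N+](=O)[O-])cc2Cl)c2ccccc12` gives 50 ug/mL
Compound 2 `CCOC(=O)C1=C(C)NC(=O)NC1c1cn(C(=O)CNc2ccc([N+](=O)[O-])cc2C)c2ccccc12` gives 50 ug/mL

Both values come from a functional assay on MCF7 cells (Homo sapiens) for cytotoxicity, read by MTT assay, with a stated time of 72 h; a higher number here means a weaker inhibitor, a lower number a stronger inhibitor. Among the compounds with values here, compound 2 stands level with compound 1, and the single measured step, no change at the digits printed from compound 1 to compound 2 (within the scatter), falls within the scatter. Compound 3 `CCOC(=O)C1=C(C)NC(=O)NC1c1cn(C(=O)CNc2ccccc2[N+](=O)[O-])c2ccccc12` differs from compound 2 by 2-nitrophenyl in place of 2-methyl-4-nitrophenyl on an amine nitrogen. Within the data shown here, no measured step covers this change directly; the only step available, from compound 1 to compound 2, showed no movement. Compound 3 is therefore expected to stay level, with an expected step of no change at the digits printed from compound 2 to compound 3 (within the scatter). For compound 3 the estimate is 50 ug/mL, with a range from 25 ug/mL to 100 ug/mL.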

Compound 3, half-maximal inhibitory concentration: 40 ug/mL
Beside the measured number, compound 3's estimate is 1.3-fold (0.10 log units) above it; low and high end bracket the measured number.
By their numbers in this assay, from the lowest: compounds 3, 1 and 2 (each within the scatter of the next).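

In this assay, putting 2-nitrophenyl on the amine nitrogen gives a 1.3-fold lower number from compound 2 to compound 3 (0.10 log units; within the scatter), and likewise a 1.3-fold lower number from compound 1 to compound 3 (0.10 log units; within the scatter). The earlier step only swapped chloro for methyl, whereas here the whole aromatic group differs, and the numbers still sit within the scatter. No measurement is available to explain this result.

The compounds shown leave open whether any change at this amine nitrogen can move the number beyond the scatter. An aromatic group carrying an amine or a carboxylic acid in place of the nitro group remains an open case.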